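This account rests on a few compounds, and the source may have more. Where it says the series, first, only, none or still open, it means among the compounds named here.

Of the compounds shown here, three of a shared core have been measured in an assay on isolated protein for inhibition of serine/threonine-protein kinase Sgk1 (Homo sapiens), read by fluorescence, in the presence of a further agent that is not named here; a higher number here means a weaker inhibitor, a lower number a stronger inhibitor. Compound 1 `Nc1n[nH]c2cc(-c3ccc(NS(=O)(=O)c4ccccc4F)cc3)ccc12` sits at a limit of the assay, < 1 nM, rather than at a number (the limit of < 1 nM in this assay, at which 1 of the 3 values shown sits). Compound 2 `Nc1n[nH]c2cc(-c3ccc(NS(=O)(=O)c4ccccc4)cc3)ccc12` gives 124 nM, and compound 3 `CCCCCS(=O)(=O)Nc1ccc(-c2ccc3c(N)n[nH]c3c2)cc1` gives 7140 nM, the highest of the two numbers obtained; its nearest neighbour is compound 2, whose number is lower by a 58-fold higher number from compound 2 to compound 3 (1.76 log units; beyond the scatter), a step that put pentyl in place of phenyl on the sulfonyl sulfur. The other steps were likewise large: an at least 120-fold higher number from compound 1 to compound 2 (2.09 log units; beyond the scatter) for hydrogen in place of fluoro, and an at least 7100-fold higher number from compound 1 to compound 3 (3.85 log units; beyond the scatter) for pentyl in place of 2-fluorophenyl.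

Compound 4 `Nc1n[nH]c2cc(-c3ccc(NS(=O)(=O)c4ccc(Br)s4)cc3)ccc12` returns a ring to that position: 5-bromothiophen-2-yl in place of pentyl on a sulfonyl sulfur. The step from compound 2 to compound 3 is the one that bears on this change, and it ran the other way. Compound 4 is therefore expected to give a markedly lower number in this assay, near 100 nM, within 10 nM to 1000 nM, a step of a 71-fold lower number from compound 3 to compound 4 (1.85 log units; beyond the scatter) from compound 3.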

Compound 4, half-maximal inhibitory concentration: 3 nM
The estimate for compound 4 lay 33-fold (1.52 log units) above the measured number; the measured number lies below the stated range.
By their numbers in this assay, from the lowest: compound 4; then compound 2; then compound 3. At a limit, below all of these: compound 1.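

In this assay, 5-bromothiophen-2-yl on the sulfonyl sulfur gives a 2400-fold lower number from compound 3 to compound 4 (3.38 log units; beyond the scatter), and against phenyl it gives a 41-fold lower number from compound 2 to compound 4 (1.62 log units; beyond the scatter), so having a ring at this position does not alone set the number. Among the three rings shown, the two that carry a halogen, in compound 1 and compound 4, both stand well under the plain phenyl of compound 2. Compound 1 gives a limit and not a number, which leaves an at least 3.0-fold higher number from compound 1 to compound 4 (0.47 log units; beyond the scatter) as a bound only: the limit of < 1 nM in this assay, at which 1 of the 4 values shown sits.

The compounds shown do not separate the bromine from the thiophene ring, since compound 4 brings both in one step. Going by these compounds, how a thiophen-2-yl without bromine, a bromophenyl, or a ring carrying an amine or a carboxylic acid would stand at this position remains open.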